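The source may report more compounds than this note shows. Statements on the series, on what has been measured and on what is new or still open speak of the compounds shown alone.

In a functional assay on HeLa cells (Homo sapiens) for cytotoxicity, read by WST assay, with a stated time of 48 h (on this read-out higher numbers stand for weaker inhibition and lower numbers for stronger inhibition), compound 1 (`COc1cccc([C@@H]2OC[C@H]([C@@H](O)c3ccc(OC)c(OC)c3)C[C@H]2C/C=C/c2ccc(OC)c(OC)c2)c1`) gives 30100 nM and compound 2 (`COc1ccc([C@@H]2OC[C@H]([C@@H](O)c3ccc(OC)c(OC)c3)C[C@H]2C/C=C/c2ccc(OC)c(OC)c2)cc1`) gives 29200 nM, so the two stand within the scatter of each other. Compound 3 (`COc1cccc([C@H]2OC[C@H]([C@@H](O)c3ccc(OC)c(OC)c3)C[C@@H]2C/C=C/c2ccc(OC)c(OC)c2)c1`) keeps the atoms and bonds of compound 1: the two compounds have the same atoms and bonds and differ only in configuration as drawn: 2 of 5 stereo elements differ; a stereocentre at a saturated ring carbon is drawn R in compound 1 and S in compound 3; a stereocentre at a saturated ring carbon is drawn R in compound 1 and S in compound 3. Each changed stereocentre, at a saturated ring carbon, is drawn R in compound 1 and S in compound 3. For the measured compounds named here, the only measured step is a 1.0-fold lower number from compound 1 to compound 2 (0.01 log units; within the scatter), a swap of 3-methoxyphenyl for 4-methoxyphenyl that lies within the scatter. Going by the values given here, it bears on this change only weakly, since no measured pair differs in configuration. No shift beyond the scatter is therefore expected, though with wide uncertainty, and the estimate amounts to a 1.3-fold lower number from compound 1 to compound 3 (0.10 log units; within the scatter). For compound 3 the expected value is 24000 nM, with an estimated range from 8000 nM to 60000 nM.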

Compound 3, half-maximal inhibitory concentration: 21800 nM
Beside the measured number, compound 3's estimate is 1.1-fold (0.04 log units) above it, and the stated range covers the measured number.
By their numbers in this assay, from the lowest: compounds 3, 2 and 1 (each within the scatter of the next).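

In this assay, for the compounds shown here, the pair gives a 1.4-fold lower number from compound 1 to compound 3 (0.14 log units; within the scatter), the first measured comparison in which configuration is the only thing that differs: the fact that compounds 1 and 3 differ only in the configuration as drawn. Both stereocentres at the saturated ring carbons are drawn R in compound 1 and S in compound 3, and this double difference leaves the two compounds within the scatter of each other. The earlier step from compound 1 to compound 2 concerned only the place of the methoxy group on the phenyl ring, so it could not show that this assay fails to separate these two drawn configurations.

The compounds shown leave open whether either stereocentre alone, or any of the other stereo elements, would give a step beyond the scatter. They also leave open whether the same holds with 4-methoxyphenyl in place of 3-methoxyphenyl, or with a phenyl ring carrying an amine or a carboxylic acid.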